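The source may report more compounds than this note shows. Statements on the series, on what has been measured and on what is new or still open speak of the compounds shown alone.

Working notes on the amide-nitrogen series

All three measured compounds share the core of compound 1, `CCCCCCCCCCCC(=O)OC[C@H](CSC[C@@H](N)C(=O)NC(C)(C)CO)OC(=O)CCCCCCCCCCC`, and differ only in the group on the amide-type nitrogen. In an assay on HEK293 cells for agonist activity at Toll-like receptor 2 (Homo sapiens) (a higher number here means that more compound is needed for the effect, a lower number that less compound is needed), compound 1 gives 15500 nM, the highest number of the three. Compound 2, `CCCCCCCCCCCC(=O)OC[C@H](CSC[C@@H](N)C(=O)NCCCCCCO)OC(=O)CCCCCCCCCCC`, gives 33 nM, and compound 3, `CCCCCCCCCCCC(=O)OC[C@H](CSC[C@@H](N)C(=O)NC(C)CCC(C)C)OC(=O)CCCCCCCCCCC`, gives 190 nM. Both departures from compound 1 lower the number sharply: a 470-fold lower number from compound 1 to compound 2 (2.67 log units; beyond the scatter), and an 82-fold lower number from compound 1 to compound 3 (1.91 log units; beyond the scatter); between the two replacements, a 5.8-fold higher number from compound 2 to compound 3 (0.76 log units; beyond the scatter).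

Compound 4, `CCCCCCCCCCCC(=O)OC[C@H](CSC[C@@H](N)C(=O)NCCCN)OC(=O)CCCCCCCCCCC`, is the next step from compound 1: 3-aminopropyl in place of 1-(hydroxymethyl)-1-methylethyl on an amide-type nitrogen. Going by the values given here, the entering 3-aminopropyl is an open chain with one hydrogen-bond donor and one hydrogen-bond acceptor, which places it nearer the 6-hydroxyhexyl of compound 2 than the 1,4-dimethylpentyl of compound 3, though it is shorter than either, and no measured pair shows how chain length alone acts here. Given a 470-fold lower number from compound 1 to compound 2 (2.67 log units; beyond the scatter) and an 82-fold lower number from compound 1 to compound 3 (1.91 log units; beyond the scatter), both large and in the same direction, a large drop in this assay is expected for compound 4, a 130-fold lower number from compound 1 to compound 4 (2.11 log units; beyond the scatter), smaller than the step to compound 2 and close to the step to compound 3. For compound 4 the expected value is 120 nM, with a range of 20 nM to 700 nM.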

Compound 4, half-maximal effective concentration: 1960 nM
The estimate for compound 4 lay 16-fold (1.21 log units) below the measured number; the measured number lies above the stated range.
By their numbers in this assay, from the lowest: compound 2; then compound 3; then compound 4; then compound 1.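

In this assay an unbranched chain on the amide-type nitrogen does not by itself bring a large drop: 3-aminopropyl in place of 1-(hydroxymethyl)-1-methylethyl gives a 7.9-fold lower number from compound 1 to compound 4 (0.90 log units; beyond the scatter) and is only a modest step, even though both groups have the same counts of hydrogen-bond donors and acceptors. The position also separates the replacements from one another, with a 10-fold higher number from compound 3 to compound 4 (1.01 log units; beyond the scatter) when 3-aminopropyl replaces 1,4-dimethylpentyl and a 59-fold higher number from compound 2 to compound 4 (1.77 log units; beyond the scatter) when amino replaces 3-hydroxypropyl on a saturated chain carbon, three bonds along the chain from the amide-type nitrogen. Nothing measured beyond these numbers bears on the reason for this order.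

Compound 2 and compound 4 differ in both chain length and terminal group, so the compounds shown cannot say which of the two sets the gap between them. A 6-aminohexyl group or a 3-hydroxypropyl group on the same nitrogen would separate the two, and a carboxylic acid at the chain end would show whether the terminal group matters beyond the amine and the alcohol.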